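The compounds below may be only part of what the source reports. "The series", "measured", "known", "first", "only" and "open" are said of these compounds alone.

Measured so far:
Compound 1 `CC(C)N(Cc1cccc(OCCCCCC(=O)O)c1)C(=O)c1ccc(-c2ccc3[nH]ccc3c2)cc1`. In an ADME assay on BJ cells (Homo sapiens) for cytotoxicity, read by CellTiter-Glo and resazurin assay, with a stated time of 72 h (on this read-out higher numbers stand for an effect only at larger amounts of compound and lower numbers for an effect already at smaller amounts), compound 1 gives a limit, > 26000 nM.
Compound 2 `CCOC(=O)CCCCCOc1cccc(CN(C(=O)c2ccc(-c3cccc(C(C)=O)c3)cc2)C(C)C)c1`. In this assay compound 2 gives a limit, > 26000 nM.
Compound 3 `CCOC(=O)CCCCCOc1cccc(CN(C(=O)c2ccc(-c3cccc(OCC(C)C)c3)cc2)C(C)C)c1`. In this assay compound 3 gives a limit, > 26000 nM.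

Compound 3 therefore stands where every value of the series stands so far: at the limit of > 26000 nM in this assay, at which 3 of the 3 values shown sit, with no number inside the tested range for any of the three. Within the data shown here, the one step between neighbours, a step that the two limits leave unreadable from compound 2 to compound 3, cannot be read for the same reason. Compound 1, which already carries the indolyl group that enters below, also sits at the limit, but it differs from compound 3 in two places, so its value only shows that the indolyl aryl is compatible with a limit read-out under its own ester-to-acid setting.

The next compound, compound 4 `CCOC(=O)CCCCCOc1cccc(CN(C(=O)c2ccc(-c3ccc4[nH]ccc4c3)cc2)C(C)C)c1`, differs from compound 3 in one place: 1H-indol-5-yl in place of 3-(isobutoxy)phenyl on an aromatic carbon. Among the measured compounds shown here, no measured step bears directly on this change, and the three limits give no direction. Hence no step beyond the scatter is expected, and the estimated step of a number no higher from compound 3 to compound 4 (the limit leaves the size open) is set at zero. For compound 4 in this assay the estimate is 26000 nM, within 12000 nM to 60000 nM, most likely reported again as a limit.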

Compound 4, half-maximal effective concentration: > 26000 nM
Compound 4 ended at the assay's limit (the forecaster's own chance of this, stated with the estimate: 85%); the middle value sits exactly at the limit.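

In this assay compound 4 gives > 26000 nM, a limit and not a number. The steps to compound 4 from compound 1, compound 2 and compound 3 therefore cannot be read, since the whole series sits at one value: the limit of > 26000 nM in this assay, at which 4 of the 4 values shown sit. The compounds shown leave open at what concentration any of them reaches a half-maximal effect, and whether the exchanged groups differ at all in this read-out.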